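This account rests on a few compounds, and the source may have more. Where it says the series, first, only, none or still open, it means among the compounds named here.

Working notes on the series. Among the measured compounds shown here, in a functional assay on SH-SY5Y cells (Homo sapiens) for antiproliferative activity, read by MTT assay, with a stated time of 72 h (a lower number here means a stronger inhibitor, a higher number a weaker inhibitor), compound 2 `FC(F)(F)c1ccc(COc2cccc(Nc3ncnc4cc5c(cc34)OCCOCCO5)c2)cc1` gives 19300 nM, the only number recorded in the set. For compound 1 `FC(F)(F)c1ccc(COc2ccccc2Nc2ncnc3cc4c(cc23)OCCOCCO4)cc1` the result is a limit of the assay, > 100000 nM, which matches (the limit of > 100000 nM in this assay, at which 1 of the 2 values shown sits). Compound 3 `O=[N+]([O-])c1ccc(COc2cccc(Nc3ncnc4cc5c(cc34)OCCOCCO5)c2)cc1` carries the change (nitro in place of trifluoromethyl on an aromatic carbon). For the measured compounds named here, no measured pair in the set shares this change, so the step from compound 2 to compound 3 in this assay can only be expected to lie within the scatter, with no direction favoured: the estimated step is a 1.0-fold higher number from compound 2 to compound 3 (0.02 log units; within the scatter). For compound 3 the expected value is 20000 nM, between 6000 nM and 65000 nM.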

Compound 3, half-maximal inhibitory concentration: 36600 nM
Compound 3: the middle estimate sits 1.8-fold (0.26 log units) below what was measured, within the range that was stated.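

In this assay, the exchange of 4-(trifluoromethyl)benzyl for 4-nitrobenzyl gives a 1.9-fold higher number from compound 2 to compound 3 (0.28 log units; within the scatter). Among the compounds shown here, this is the first measured step in the set, and it leaves the two groups indistinguishable at this position, although nitro brings 2 hydrogen-bond acceptors and trifluoromethyl none. Nothing recorded for the set bears on the reason for this step.

Going by these compounds, whether an amine or a carboxylic acid at this position would read the same remains open. Also open, on these data alone, is how nitro would read on compound 1, whose value is a limit of the assay.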